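An aryl swap on a weakly active ester series

The compounds below may be only part of what the source reports. "The series", "measured", "known", "first", "only" and "open" are said of these compounds alone.

Compound 1 `C/C(=C\CC/C(C)=C/CC[C@@H]1[C@@]2(C)CCC(=O)C(C)(C)[C@H]2CC[C@@]1(C)O)CC/C=C(\C)C(=O)OCc1cn(-c2ccc([N+](=O)[O-])cc2)nn1` gives > 150000 nM in a functional assay on DU-145 cells (Homo sapiens) for antiproliferative activity, read by MTT assay, with a stated time of 48 h; on this read-out lower numbers stand for stronger inhibition and higher numbers for weaker inhibition.
Compound 2 `C/C(=C\CC/C(C)=C/CC[C@@H]1[C@@]2(C)CCC(=O)C(C)(C)[C@H]2CC[C@@]1(C)O)CC/C=C(\C)C(=O)OCc1cn(-c2ccc(F)c(Cl)c2)nn1` gives > 150000 nM in this assay.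
Compound 3 `C/C(=C\CC/C(C)=C/CC[C@@H]1[C@@]2(C)CCC(=O)C(C)(C)[C@H]2CC[C@@]1(C)O)CC/C=C(\C)C(=O)OCc1cn(-c2cccc(Cl)c2)nn1` gives 103000 nM in this assay.

Compound 2 stands at a limit of this assay rather than at a number, as the limit of > 150000 nM in this assay, at which 2 of the 3 values shown sit, shows. Compound 3 alone gives a number, and that number is very high. Compound 4 `COc1cccc(-n2cc(COC(=O)/C(C)=C/CC/C(C)=C/CC/C(C)=C/CC[C@@H]3[C@@]4(C)CCC(=O)C(C)(C)[C@H]4CC[C@@]3(C)O)nn2)c1` has not been measured; its change from compound 2 is 3-methoxyphenyl in place of 3-chloro-4-fluorophenyl on an aromatic nitrogen.

For the measured compounds named here, the steps that bear on this change all alter the same aryl group: a step that the two limits leave unreadable from compound 1 to compound 2, an at least 1.4-fold lower number from compound 1 to compound 3 (0.16 log units; that floor lies within the scatter) and an at least 1.4-fold lower number from compound 2 to compound 3 (0.16 log units; that floor lies within the scatter). None of them is readable as a step beyond the scatter, so the aryl substituent seems to move the read-out little, if at all, in this set. Accordingly, no change beyond the scatter is expected, and the estimated step is a number no higher from compound 2 to compound 4 (the limit leaves the size open). Compound 4 is therefore expected to give about 150000 nM, within a range from 80000 nM to 300000 nM, quite possibly again as a limit only.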

Compound 4, half-maximal inhibitory concentration: > 150000 nM
Compound 4 ended at the assay's limit; the forecaster's own chance of this, stated with the estimate: 60%; the middle value lies on the limit itself.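

For the compounds shown here, the one new step that can be read in this assay is an at least 1.4-fold higher number from compound 3 to compound 4 (0.16 log units; that floor lies within the scatter). The steps from compound 1 and from compound 2 to compound 4 cannot be read, because all three compounds sit at the same limit: the limit of > 150000 nM in this assay, at which 3 of the 4 values shown sit. Going by these compounds alone, the 3-methoxyphenyl group of compound 4 carries a hydrogen-bond acceptor that the 3-chloro-4-fluorophenyl group of compound 2 lacks, yet this swap on the aromatic nitrogen gives no readable gain, and no step among the four aryl groups lies beyond the scatter.

The compounds shown leave open whether an aryl ring carrying an amine or a carboxylic acid would give a clear number in this assay. They also leave open whether replacing the ester link, common to all four, would matter more than the aryl group.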